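Methyl(propyl)amino in Place of tert-Butylamino: An Expected Step

The source may report more compounds than this note shows. Statements on the series, on what has been measured and on what is new or still open speak of the compounds shown alone.

Three compounds have been measured in an ADME assay on the whole organism for inhibition, with Oryza sativa as the target, with a stated time of 4 days; a higher number here means a weaker inhibitor, a lower number a stronger inhibitor:

Compound 1, `C[C@H](Nc1nc(Cl)nc(NC(C)(C)C)n1)c1ccccc1`: 3310 nM
Compound 2, `CCCN(CC)c1nc(Cl)nc(N[C@@H](C)c2ccccc2)n1`: 479 nM
Compound 3, `CCCCNc1nc(Cl)nc(N[C@@H](C)c2ccccc2)n1`: 23400 nM

Compound 1 stands second highest of the three numbers. Compound 2 lies below it, with a 6.9-fold lower number from compound 1 to compound 2 (0.84 log units; beyond the scatter), and compound 3 lies above it, with a 7.1-fold higher number from compound 1 to compound 3 (0.85 log units; beyond the scatter). Across the two, a 49-fold higher number from compound 2 to compound 3 (1.69 log units; beyond the scatter).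

Compound 4, `CCCN(C)c1nc(Cl)nc(N[C@@H](C)c2ccccc2)n1`, differs from compound 1 by methyl(propyl)amino in place of (tert-butyl)amino on an aromatic carbon. The step from compound 1 to compound 2 bears on this directly, since it too replaces (tert-butyl)amino with a dialkylamino group on the same aromatic carbon, and it gave a modest lower number. The step from compound 2 to compound 3 points the same way, a dialkylamino group sitting well below a monoalkylamino one. Compound 4 is therefore expected to give a lower number than compound 1, a step of roughly the size seen from compound 1 to compound 2, that is a 5.1-fold lower number from compound 1 to compound 4 (0.71 log units; beyond the scatter). The estimate for compound 4 in this assay is 650 nM, expected to fall between 220 nM and 2000 nM.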

Compound 4, half-maximal inhibitory concentration: 5500 nM
Estimate against measurement, compound 4: 8.5-fold (0.93 log units) below, and the stated range ends below it.
By their numbers in this assay, from the lowest: compound 2; then compounds 1 and 4 (each within the scatter of the next); then compound 3.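

Placing methyl(propyl)amino in place of (tert-butyl)amino on this aromatic carbon, with the same atoms in each group, makes no clear difference in this assay, with a 1.7-fold higher number from compound 1 to compound 4 (0.22 log units; within the scatter). Having two alkyl groups on this nitrogen is therefore not enough to give the lower number, since the one-place change from ethyl to methyl on it produces an 11-fold higher number from compound 2 to compound 4 (1.06 log units; beyond the scatter). Methyl(propyl)amino and butylamino also differ clearly despite having the same atoms, with a 4.3-fold lower number from compound 3 to compound 4 (0.63 log units; beyond the scatter).

Nothing available explains why these groups differ in this way. From the compounds shown here alone, what remains open is whether diethylamino, dipropylamino or a cyclic amine such as pyrrolidine at this position would give a number as low as that of compound 2, 479 nM.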